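Working notes: furan-2-yl in place of thiophen-2-yl

The source may report more compounds than this note shows. Statements on the series, on what has been measured and on what is new or still open speak of the compounds shown alone.

Among the compounds with values here, in an ADME assay on J774.A1 cells (Mus musculus) for cytotoxicity, read by MTT assay, with a stated time of 72 h (a lower number here means that less compound is tolerated, a higher number that more compound is tolerated), compound 1 `Fc1ccc(F)c(COC(CCn2ccnc2)c2cccs2)c1` gives 15100 nM, the only number available, so it cannot yet be ranked against any other compound. For compound 2 `Fc1ccc(COC(CCn2cncn2)c2cccs2)c(F)c1` the entry reads "not determined" (no result reported). Compound 3 `Fc1ccc(F)c(COC(CCn2ccnc2)c2ccco2)c1` carries furan-2-yl in place of thiophen-2-yl on a saturated chain carbon bound to an oxygen on a saturated carbon and a saturated chain carbon. Within the data shown here, no measured pair shows this change, and only the hetero atom of the ring differs. In this assay no step beyond the scatter is expected, and neither direction is favoured. The expected step is a 1.0-fold lower number from compound 1 to compound 3 (0.00 log units; within the scatter). Compound 3 is estimated at 15000 nM, with an expected range of 7000 nM to 32000 nM.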

Compound 3, half-maximal cytotoxic concentration: 30900 nM
The estimate for compound 3 lay 2.1-fold (0.31 log units) below the measured number; the range from low to high includes it.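

Within the data shown here, at this saturated chain carbon, furan-2-yl in place of thiophen-2-yl gives in this assay a 2.0-fold higher number from compound 1 to compound 3 (0.31 log units; beyond the scatter) and thus the first measured step. Exchanging only the hetero atom of the ring is therefore enough to move the number beyond the usual scatter, towards more compound tolerated, although the step is modest. No measurement shown explains this step.

A single pair cannot show whether the step would recur with other substituents on the shared core. As far as these compounds go, how a phenyl or pyridin-2-yl group at this carbon would compare also remains open.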